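This account rests on a few compounds, and the source may have more. Where it says the series, first, only, none or still open, it means among the compounds named here.

Series notes. Among the measured compounds shown here, compound 2 `CCCSc1nc(=O)ccn1[C@@H]1O[C@H](COP(=O)(O)OP(=O)(O)O)[C@@H](O)[C@H]1O` gives 1200 nM in an in vitro functional assay on 1321-N1 cells for agonist activity at P2Y purinoceptor 2 (Homo sapiens), read by scintillation proximity assay and inositol phosphate accumulation (on this read-out lower numbers stand for an effect already at smaller amounts and higher numbers for an effect only at larger amounts of compound), the second highest of the three numbers so far; compound 1 `CCSc1nc(=O)ccn1[C@@H]1O[C@H](COP(=O)(O)O)[C@@H](O)[C@H]1O` gives 1500 nM and compound 3 `COc1nc(=O)ccn1[C@@H]1O[C@H](COP(=O)(O)OP(=O)(O)O)[C@@H](O)[C@H]1O` gives 907 nM, both within the scatter of compound 2. For the measured compounds named here, the only single-point step measured, a 1.3-fold lower number from compound 2 to compound 3 (0.12 log units; within the scatter), exchanges the group on the aromatic carbon and leaves the phosphate part untouched. Compound 4 `CCCSc1nc(=O)ccn1[C@@H]1O[C@H](COP(=O)(O)O)[C@@H](O)[C@H]1O` differs from compound 2 by a hydrogen atom in place of a group of 4 heavy atoms (3 oxygen, 1 phosphorus; no ring), on an oxygen whose other neighbour is phosphorus. Going by the values given here, no measured step covers this change directly; compound 1 carries the same single phosphate and sits at 1500 nM, within the scatter of compound 2, so no step beyond the scatter is expected. For compound 4 the estimate is 1600 nM (range 700 nM to 4000 nM), corresponding to an expected 1.3-fold higher number from compound 2 to compound 4 (0.12 log units; within the scatter).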

Compound 4, half-maximal effective concentration: 4800 nM
Compound 4: middle estimate off by 3.0-fold (0.48 log units), on the low side; the measured number lies above the stated range.
By their numbers in this assay, from the lowest: compounds 3, 2 and 1 (each within the scatter of the next); then compound 4.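

Among the compounds shown here, with the propylsulfanyl group kept, a hydrogen atom in place of the group of 4 heavy atoms on the oxygen gives a 4.0-fold higher number from compound 2 to compound 4 (0.60 log units; beyond the scatter), the first change at this position to lie beyond the scatter. With the single phosphate kept, methyl in place of hydrogen on the saturated chain carbon gives a 3.2-fold higher number from compound 1 to compound 4 (0.51 log units; beyond the scatter), so the number of compound 1 does not carry over to compound 4. No measurement on hand accounts for either step.

From the compounds shown here alone, whether the same change on the oxygen moves the number as far with methoxy on the aromatic carbon stays open. A third phosphate on the chain, or a butyl chain on the sulfur, also remains untested in the compounds shown.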